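From Phenylsulfanyl to 4-Bromophenoxy: An Expected Small Step

The compounds below may be only part of what the source reports. "The series", "measured", "known", "first", "only" and "open" are said of these compounds alone.

Compounds measured so far:
- compound 1 `O=c1cc(-n2cc(CSc3ccccc3)nn2)c2cc(Br)ccc2o1`, in a functional assay on SW480 cells (Homo sapiens) for antiproliferative activity, read by MTT assay, with a stated time of 48 h (a lower number here means a stronger inhibitor, a higher number a weaker inhibitor), compound 1 gives 15400 nM
- compound 2 `O=c1cc(-n2cc(COc3ccnc4ccc(Br)cc34)nn2)c2cc(Br)ccc2o1`, in this assay compound 2 gives 17000 nM

For the measured compounds named here, only two compounds have been measured, and both sit in the same region: compound 1 and compound 2 differ by a gap that lies within the usual scatter of this assay, so neither can be called the more or less active of the two. Compound 1 is one of this pair of similar numbers.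

The next compound, compound 3 `O=c1cc(-n2cc(COc3ccc(Br)cc3)nn2)c2cc(Br)ccc2o1`, keeps the shared core of compound 1 and changes one side group: 4-bromophenoxy in place of phenylsulfanyl on a saturated chain carbon bound to an aromatic carbon. Going by the values given here, no measured pair shows the effect of exactly this exchange, so the expectation rests on the fact that two rather different side groups, in compound 1 and compound 2, gave much the same number. On that basis the step in this assay is expected to be small and without a clear direction, most likely no larger than the scatter itself. Compound 3 is therefore estimated at 15000 nM, with a plausible range from 6000 nM to 40000 nM, which corresponds to an expected step of a 1.0-fold lower number from compound 1 to compound 3 (0.01 log units; within the scatter).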

Compound 3, half-maximal inhibitory concentration: 1310 nM
The estimate for compound 3 lay 11-fold (1.06 log units) above the measured number, and the stated range ends above it.
By their numbers in this assay, from the lowest: compound 3; then compounds 1 and 2 (each within the scatter of the next).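

In this assay, for the compounds shown here, 4-bromophenoxy in place of phenylsulfanyl on a saturated chain carbon bound to an aromatic carbon gives a 12-fold lower number from compound 1 to compound 3 (1.07 log units; beyond the scatter) and so a stronger inhibitor, the first gap beyond the scatter and the first sign that the group at this position can matter for this activity. The change is small on paper: both groups hold one six-membered aromatic ring of carbon only, with the same counts of hydrogen-bond donors and acceptors and no net charge, so what differs is an oxygen where a sulfur stood, plus a bromine. Nothing available explains why this exchange has so large an effect.

The compounds shown leave open whether the oxygen, the bromine or only the two together account for the step, a question that plain phenoxy and 4-bromophenylsulfanyl at this position could separate. Also open, as far as these compounds go, is how far the trend extends, for instance to 4-chlorophenoxy or to an amine in place of the oxygen.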